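The compounds below may be only part of what the source reports. "The series", "measured", "known", "first", "only" and "open" are said of these compounds alone.

Measured compounds:
- compound 1 `Cc1cccc(COc2ccc(C(=O)Nc3cccc(C(=O)O)c3)cc2)c1`: in an assay on isolated protein for agonist activity at Bile acid receptor (Homo sapiens), read by TR-FRET, with a stated time of 3 h, in the absence of a further agent (on this read-out higher numbers stand for an effect only at larger amounts of compound and lower numbers for an effect already at smaller amounts), compound 1 gives 259 nM
- compound 2 `O=C(O)c1cccc(NC(=O)c2ccc(OCc3cccc(-c4ccccc4)c3)cc2)c1`: in this assay compound 2 gives 319 nM

Among the measured compounds shown here, of the two numbers, compound 2 carries the higher one, yet its only neighbour, compound 1, differs from it by a 1.2-fold higher number from compound 1 to compound 2 (0.09 log units; within the scatter), a gap that lies within the scatter of repeated measurements, so the two compounds cannot be told apart on this evidence.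

Compound 3 `Cc1ccccc1-c1cccc(COc2ccc(C(=O)Nc3cccc(C(=O)O)c3)cc2)c1` has not yet been measured. Compared with compound 2 the change is methyl in place of hydrogen on an aromatic carbon. For the measured compounds named here, only one measured step touches this part of the molecule: the exchange of methyl for phenyl on the aromatic carbon, which moved the number by a 1.2-fold higher number from compound 1 to compound 2 (0.09 log units; within the scatter), that is, not beyond the scatter. Adding a methyl to the phenyl that was introduced there is a smaller change than the one already tested, and nothing in the data points to a direction. The expectation is therefore a step of no more than the scatter, in either direction. On this basis compound 3 is expected to give about 320 nM, with a likely range from 120 nM to 900 nM. This estimate means an expected 1.0-fold higher number from compound 2 to compound 3 (0.00 log units; within the scatter).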

Compound 3, half-maximal effective concentration: 1030 nM
Estimate against measurement, compound 3: 3.2-fold (0.51 log units) below; measured number above the stated range.
By their numbers in this assay, from the lowest: compounds 1 and 2 (each within the scatter of the next); then compound 3.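

In this assay this position turns out to be sensitive: the exchange of methyl for phenyl gave no readable change, yet a single methyl added to that phenyl, ortho to a large group, gives a 3.2-fold higher number from compound 2 to compound 3 (0.51 log units; beyond the scatter) and so lies beyond the scatter, though the step is modest. Set directly against the small methyl of compound 1, the 2-methylphenyl group gives a 4.0-fold higher number from compound 1 to compound 3 (0.60 log units; beyond the scatter) and likewise needs more compound for the same effect, so the tolerance seen with the plain phenyl does not extend to this group. Nothing measured here explains why one added carbon matters more than the larger exchange did.

Still open, as far as these compounds go, is whether this step is particular to methyl or would appear with other groups in the same place, such as chlorine, methoxy or hydroxyl. Also open, from the compounds shown here alone, is whether the place itself matters, which a methyl elsewhere on the phenyl would test, since one compound cannot separate the identity of the group from where it sits.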